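Swapping the Outer Aryl Ring: Lipophilicity Expectation for Compound 4

This account rests on a few compounds, and the source may have more. Where it says the series, first, only, none or still open, it means among the compounds named here.

Measured compounds:
- compound 1, `CC[C@@H](Nc1c(C#N)c(-c2ccc(-c3ncccc3C)cc2)nc2cnccc12)C(N)=O`, gives 2 in a physicochemical assay for lipophilicity, read by HPLC, at pH 7.5; on this read-out higher numbers stand for higher lipophilicity and lower numbers for lower lipophilicity
- compound 2, `CC[C@@H](Nc1c(C#N)c(-c2ccc(-c3ccccc3C(F)(F)F)cc2)nc2cnccc12)C(N)=O`, gives 3.1
- compound 3, `CC[C@@H](Nc1c(C#N)c(-c2ccc(-c3ccc(Cl)cc3)cc2)nc2cnccc12)C(N)=O`, gives 3.1

All three share one core and differ only in the outer aromatic ring attached to it. Compound 3 stands level with compound 2 at the digits shown, and the two together sit at the top of the three numbers; compound 1 sits furthest away, a number 1.10 log units higher from compound 1 to compound 3 (beyond the scatter). The other two steps are a number 1.10 log units higher from compound 1 to compound 2 (beyond the scatter) and no change at the digits printed from compound 2 to compound 3 (within the scatter).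

Compound 4, `CC[C@@H](Nc1c(C#N)c(-c2ccc(-c3cccc(Cl)c3OC)cc2)nc2cnccc12)C(N)=O`, has not yet been measured. It differs from compound 3 by 3-chloro-2-methoxyphenyl in place of 4-chlorophenyl on an aromatic carbon. Among the compounds with values here, the step most closely bearing on this change is the one between compound 2 and compound 3, where one carbon-only ring replaced another and the read-out did not move beyond the scatter. The two large steps from compound 1 both involved a 3-methylpyridin-2-yl ring leaving, which does not happen here. The expectation is therefore a step of about no change at the digits printed from compound 3 to compound 4 (within the scatter), that is, none beyond the scatter. Compound 4 is estimated to give 3.1, within a range from 2.7 to 3.5.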

Compound 4, distribution coefficient: 3.1
Compound 4: the middle estimate sits on the measured number at the digits printed, within the range that was stated.
By their numbers in this assay, from the lowest: compound 1; then compounds 2, 3 and 4 (each within the scatter of the next).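

In this assay, on an aromatic carbon para to a large group, 3-chloro-2-methoxyphenyl in place of 4-chlorophenyl gives no change at the digits printed from compound 3 to compound 4 (within the scatter), even though the entering group has 9 heavy atoms against 7 and brings 1 hydrogen-bond acceptor where the leaving group has 0. The new ring also reads level with the other carbon-only ring, with no change at the digits printed from compound 2 to compound 4 (within the scatter), while it stands well apart from the 3-methylpyridin-2-yl ring, with a number 1.10 log units higher from compound 1 to compound 4 (beyond the scatter), so among these four compounds the three carbon-only rings sit together and compound 1 alone sits lower, with no compound going against that grouping. Nothing available here explains why the added methoxy group leaves the number where it is.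

The compounds shown leave open how this assay would respond to an outer ring carrying an amine or a carboxylic acid at this position. They also leave open what the methoxy group and the chlorine each contribute alone, as a plain 2-methoxyphenyl or 3-chlorophenyl ring would show.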